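A Nitrile-Bearing Phenyl Replaces Pyridine on the Outer Ring

The source may report more compounds than this note shows. Statements on the series, on what has been measured and on what is new or still open speak of the compounds shown alone.

Compound 3 `CC(C)C[C@H](N)CN(C(=O)[C@@H]1C[C@H]1c1ccccc1)c1ccc(-c2cccnc2)cc1` gives 10000 nM in a functional assay for agonist activity at G protein-coupled receptor 88 (Homo sapiens), read by HTRF and cAMP accumulation (a higher number here means that more compound is needed for the effect, a lower number that less compound is needed), the highest of the three numbers measured. Compound 1 `CC[C@H](C)[C@H](N)CN(C(=O)[C@@H]1C[C@H]1c1ccc(F)c(F)c1)c1ccc(-c2ccccc2)cc1` gives 720 nM in this assay, and compound 2 `CC[C@H](C)[C@H](N)CN(C(=O)[C@@H]1C[C@H]1c1csc(C)n1)c1ccc(-c2ccccc2)cc1` gives 1500 nM. Compound 4 `CC(C)C[C@H](N)CN(C(=O)[C@@H]1C[C@H]1c1ccccc1)c1ccc(-c2cccc(C#N)c2)cc1` differs from compound 3 by 3-cyanophenyl in place of pyridin-3-yl on an aromatic carbon. For the measured compounds named here, the single measured step, a 2.1-fold higher number from compound 1 to compound 2 (0.32 log units; beyond the scatter), concerns the group on the saturated ring rather than the outer aromatic ring, so it offers no direct guide, and compounds 1 and 2 differ from compound 3 in several further places at once. With nothing bearing on this change, compound 4 is expected to show only a 1.7-fold lower number from compound 3 to compound 4 (0.22 log units; within the scatter), a shift that may not exceed the scatter. Compound 4 is therefore estimated at 6000 nM, within 1500 nM to 20000 nM.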

Compound 4, half-maximal effective concentration: 4500 nM
Beside the measured number, compound 4's estimate is 1.3-fold (0.12 log units) above it; measured number inside the range.
By their numbers in this assay, from the lowest: compound 1; then compound 2; then compound 4; then compound 3.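

Changing the outer ring, on an aromatic carbon para to a large group, does shift the result in this assay, with a 2.2-fold lower number from compound 3 to compound 4 (0.35 log units; beyond the scatter). The two groups have the same hydrogen-bond acceptor count, so that count alone does not separate compound 3 from compound 4. No measurement available here explains the shift.

On these data alone, it remains open whether the nitrile matters or the carbon-only ring alone is enough. Plain phenyl on the same core would separate those two, and 3-methoxyphenyl would show whether another group can take the nitrile's place.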